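Shrinking the Ring on the Core Nitrogen

This account rests on a few compounds, and the source may have more. Where it says the series, first, only, none or still open, it means among the compounds named here.

Three compounds share one core and differ only in the group on the aromatic nitrogen. Compound 1 `CCn1c(-c2ccc(OCc3c(-c4c(Cl)cccc4Cl)noc3C(C)C)cc2)nc2ccc(C(=O)O)cc21` gives 2.31 nM in an assay on Huh-7 cells for agonist activity at Bile acid receptor (Homo sapiens), read by a luciferase reporter (on this read-out higher numbers stand for an effect only at larger amounts of compound and lower numbers for an effect already at smaller amounts), compound 2 `CC(C)c1onc(-c2c(Cl)cccc2Cl)c1COc1ccc(-c2nc3ccc(C(=O)O)cc3n2C2CCCCCC2)cc1` gives 14.8 nM, and compound 3 `CC(=O)N1CCC(n2c(-c3ccc(OCc4c(-c5c(Cl)cccc5Cl)noc4C(C)C)cc3)nc3ccc(C(=O)O)cc32)CC1` gives 1430 nM. Compound 3 stands highest of the three: a 620-fold higher number from compound 1 to compound 3 (2.79 log units; beyond the scatter) and a 97-fold higher number from compound 2 to compound 3 (1.99 log units; beyond the scatter), whereas a 6.4-fold higher number from compound 1 to compound 2 (0.81 log units; beyond the scatter) was only modest. Compound 4 `CC(C)c1onc(-c2c(Cl)cccc2Cl)c1COc1ccc(-c2nc3ccc(C(=O)O)cc3n2C2CCC2)cc1` carries cyclobutyl in place of 1-acetylpiperidin-4-yl on an aromatic nitrogen. Cyclobutyl is a carbon-only ring, smaller than the cycloheptyl of compound 2 and larger than the ethyl of compound 1, so the numbers for those two compounds frame what is expected, and a large drop in this assay is anticipated, a 320-fold lower number from compound 3 to compound 4 (2.50 log units; beyond the scatter). Compound 4 is estimated at 4.5 nM, expected to fall between 1.5 nM and 20 nM.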

Compound 4, half-maximal effective concentration: 14.4 nM
Estimate against measurement, compound 4: 3.2-fold (0.51 log units) below; low and high end bracket the measured number.
By their numbers in this assay, from the lowest: compound 1; then compounds 4 and 2 (each within the scatter of the next); then compound 3.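

Replacing 1-acetylpiperidin-4-yl with cyclobutyl recovers most of the lost ground (a 99-fold lower number from compound 3 to compound 4 (2.00 log units; beyond the scatter)), so a ring on this nitrogen is not poorly tolerated in itself. Among the carbon-only rings, the step from cycloheptyl to cyclobutyl makes no readable difference (a 1.0-fold lower number from compound 2 to compound 4 (0.01 log units; within the scatter)), and yet cyclobutyl still does not match ethyl (a 6.2-fold higher number from compound 1 to compound 4 (0.79 log units; beyond the scatter)). No measurement shown here explains these differences. From the compounds shown here alone, it remains open whether the loss in compound 3 follows the ring nitrogen or the acetyl group, and how a piperidine with a free amine would read.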